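Phenyl in Place of Methyl on the Shared Core

The compounds below may be only part of what the source reports. "The series", "measured", "known", "first", "only" and "open" are said of these compounds alone.

Measured so far:
compound 1 `C#CCOc1ccc(-c2cc(-c3ccccc3OCC#C)nc(N)n2)cc1` — 28600 nM
compound 2 `C#CCOc1ccc(-c2cc(-c3ccc(OCC#C)cc3)nc(-c3ccccc3)n2)cc1` — 25600 nM
compound 3 `C#CCOc1ccc(-c2cc(-c3ccccc3OCC#C)nc(C)n2)cc1` — 23200 nM

In an assay on BTI-TN-5B1-4 cells for inhibition of Amine oxidase [flavin-containing] A (Homo sapiens), read by fluorescence and Amplex Red, using microsomes, with a stated time of 30 min (a lower number here means a stronger inhibitor, a higher number a weaker inhibitor), compound 3 gives 23200 nM. Compound 1 and compound 2 give numbers within the scatter of it, so the three cannot be told apart on this assay. Compound 4 `C#CCOc1ccc(-c2cc(-c3ccccc3OCC#C)nc(-c3ccccc3)n2)cc1` differs from compound 3 by phenyl in place of methyl on an aromatic carbon. Within the data shown here, only one measured step touches this place: a 1.2-fold lower number from compound 1 to compound 3 (0.09 log units; within the scatter), an exchange at the same aromatic carbon that stayed within the scatter. Compound 2 carries a phenyl at this position on a core with a different arrangement of the propargyloxy groups, and in this assay compound 2 gives 25600 nM, close to the number of compound 3. The account therefore expects no step beyond the scatter, a 1.0-fold higher number from compound 3 to compound 4 (0.01 log units; within the scatter). For compound 4 the estimated value in this assay is 24000 nM, with a range from 12000 nM to 48000 nM.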

Compound 4, half-maximal inhibitory concentration: 22000 nM
For compound 4 the middle estimate is 1.1-fold (0.04 log units) above the measured one; the measured number falls inside the stated range.
By their numbers in this assay, from the lowest: compounds 4, 3, 2 and 1 (each within the scatter of the next).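

On the aromatic carbon between two ring nitrogen atoms, phenyl in place of methyl gives a 1.1-fold lower number from compound 3 to compound 4 (0.02 log units; within the scatter) in this assay, and phenyl in place of amino gives a 1.3-fold lower number from compound 1 to compound 4 (0.11 log units; within the scatter), so amino, methyl and phenyl cannot be told apart at this position. The different arrangement of the propargyloxy groups gives a 1.2-fold lower number from compound 2 to compound 4 (0.07 log units; within the scatter), so it does not separate these compounds either. No outside data bear on this result. Going by these compounds, whether a carboxylic acid or a longer chain at this carbon would give a step beyond the scatter remains open.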